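The source may report more compounds than this note shows. Statements on the series, on what has been measured and on what is new or still open speak of the compounds shown alone.

Working notes on the series.

Three compounds share one core. Compound 1 `CCCCc1nc(=O)c(S(=O)(=O)c2ccc(-c3ccnc(NC(=O)C4CC4)c3)cc2)c(O)n1-c1c(OC)cccc1OC` gives 84% in an ADME assay on microsomes from liver (Homo sapiens) for metabolic stability, using NADPH, with a stated time of 10 min; a lower number here means that less of the compound is left, a higher number that more of the compound is left. Compound 2 `CCCCc1nc(=O)c(S(=O)(=O)c2ccc(-c3ccc(F)cc3)cc2)c(O)n1-c1c(OC)cccc1OC` gives 100% in this assay. Compound 3 `CCCCc1nc(=O)c(S(=O)(=O)c2ccc(-c3cccnc3)cc2)c(O)n1-c1c(OC)cccc1OC` gives 88% in this assay. Compound 3 thus sits within the scatter of compound 1, the step being a number 4 percentage points higher from compound 1 to compound 3 (within the scatter), and stands beneath compound 2, as a number 12 percentage points lower from compound 2 to compound 3 (beyond the scatter) shows. The swap of 4-fluorophenyl for the acylaminopyridinyl gave a number 16 percentage points higher from compound 1 to compound 2 (beyond the scatter).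

Compound 4 `CCCCc1nc(=O)c(S(=O)(=O)c2ccc(-c3ccc(F)nc3)cc2)c(O)n1-c1c(OC)cccc1OC` is not yet measured in this assay. Its change from compound 3 is fluoro in place of hydrogen on an aromatic carbon, on an aromatic carbon of a six-membered aromatic ring with one nitrogen, next to the ring nitrogen, para to a large group. Going by the values given here, no measured step is a plain fluoro-for-hydrogen swap, so the bearing of the measured steps is indirect; the steps that touch compound 3 were modest or within the scatter. A step of a number 4 percentage points higher from compound 3 to compound 4 (within the scatter) is therefore expected, small and possibly upward. Compound 4 is estimated at 92%, with a range from 80% to 100%.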

Compound 4, percent of the compound remaining: 100%
For compound 4 the middle estimate is 8 percentage points below the measured one; the measured number falls inside the stated range.
By their numbers in this assay, from the lowest: compounds 1 and 3 (each within the scatter of the next); then compounds 2 and 4 (each within the scatter of the next).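

Fluoro in place of hydrogen on the pyridin-3-yl ring, next to the ring nitrogen and para to a large group, is the only plain swap of this kind in the series, and in this assay it gives a number 12 percentage points higher from compound 3 to compound 4 (beyond the scatter). With 6-fluoropyridin-3-yl, the gap to the 4-fluorophenyl seen with the unsubstituted pyridin-3-yl is no longer present, with no change at the digits printed from compound 2 to compound 4 (within the scatter), while the acylaminopyridinyl comparison reads a number 16 percentage points higher from compound 1 to compound 4 (beyond the scatter). Nothing at hand accounts for the size of this single-atom step.

On these data alone, it remains open whether this position is specific to fluoro or would respond similarly to a chlorine, a methoxy group or an amine. Also open, as far as these compounds go, is whether the same swap would behave alike elsewhere on the pyridine ring.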